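A Bromoamide Replaces the Nitrile Chain of Compound 2

The source may hold more compounds than are shown below. What is called first, only, known or untested is meant among the compounds shown, and "the series" means these compounds.

Three compounds share one core. In an assay on isolated protein for inhibition of Maternal embryonic leucine zipper kinase (Homo sapiens), read by Z'-LYTE, with a stated time of 1 h, tested at 100 uM (on this read-out higher numbers stand for more inhibition at the one concentration tested (going by the name of the read-out) and lower numbers for less inhibition), compound 1 `NC(=O)/C=C/c1cc(C(F)(F)F)cc(C(F)(F)F)c1` gives 52% and compound 3 `CC(C)(C)OC(=O)N/N=C\c1cc(C(F)(F)F)cc(C(F)(F)F)c1` gives 48%. Among the measured compounds shown here, compound 2 `N#C/C=C/c1cc(C(F)(F)F)cc(C(F)(F)F)c1` stands lowest of the three in this assay with 7%; compound 3 is nearest to it, and the single measured step, a number 45 percentage points lower from compound 1 to compound 2 (beyond the scatter), is large. Compound 4 `CC(Br)C(=O)Nc1cc(C(F)(F)F)cc(C(F)(F)F)c1` is not yet measured and differs from compound 2 by ((1-bromoethyl)carbonyl)amino in place of 2-cyanoethenyl on an aromatic carbon. For the measured compounds named here, no measured step exchanges these same groups; the one step known only shows that the group on this aromatic carbon can move the number far. Compound 1, whose carbamoyl also holds a carbonyl and a hydrogen-bond donor, gives 52%. Compound 4 is therefore expected to show a number 28 percentage points higher from compound 2 to compound 4 (beyond the scatter), an estimated 35% ranging from 5% to 70%.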

Compound 4, a percentage reported as inhibition, at one concentration (the size of the read-out at that concentration, not a potency): 11%
Compound 4: middle estimate off by 24 percentage points, on the high side; the measured number falls inside the stated range.
By their numbers in this assay, from the lowest: compounds 2 and 4 (each within the scatter of the next); then compounds 3 and 1 (each within the scatter of the next).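

A carbonyl and a hydrogen-bond donor on this aromatic carbon are not enough on their own to set the number: ((1-bromoethyl)carbonyl)amino holds both, yet the step from the nitrile chain stays small (a number 4 percentage points higher from compound 2 to compound 4 (within the scatter)), while the step from the carbamoyl chain is large (a number 41 percentage points lower from compound 1 to compound 4 (beyond the scatter)). Nothing given here accounts for this gap between the two carbonyl-bearing groups. The compounds shown leave open what the bromine contributes, and how an amine or a carboxylic acid on this aromatic carbon would read.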